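The source may hold more compounds than are shown below. What is called first, only, known or untested is meant among the compounds shown, and "the series" means these compounds.

Two compounds share one core. In an assay on HeLa cells for displacement of a labelled ligand from 5-hydroxytryptamine receptor 6 (Homo sapiens) (on this read-out higher numbers stand for weaker inhibition and lower numbers for stronger inhibition), compound 1 `O=S(=O)(c1cccc2ccccc12)c1cccc2nc(N3CCNCC3)oc12` gives 7.1 nM, while compound 2 `CCCN1CCN(c2nc3c(S(=O)(=O)c4cccc5ccccc45)cccc3o2)CC1` gives 36 nM, the higher of the two numbers and beyond the scatter from compound 1. Compound 3 `O=S(=O)(c1cccc2ccccc12)c1cccc2oc(N3CCN(C4CCCC4)CC3)nc12` differs from compound 2 by cyclopentyl in place of propyl on an amine nitrogen in a ring. Going by the values given here, no measured pair shows this change, so the step from propyl to cyclopentyl is expected to be small, at most a mild weakening, giving a 1.4-fold higher number from compound 2 to compound 3 (0.14 log units; within the scatter). Compound 3 is therefore estimated at 50 nM in this assay, with a range from 15 nM to 160 nM.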

Compound 3, inhibition constant: 79 nM
For compound 3 the middle estimate is 1.6-fold (0.20 log units) below the measured one; the range from low to high includes it.
By their numbers in this assay, from the lowest: compound 1; then compound 2; then compound 3.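

In this assay, cyclopentyl in place of propyl on the amine nitrogen in the ring gives a 2.2-fold higher number from compound 2 to compound 3 (0.34 log units; beyond the scatter) as a modest step, so this position registers the change and the larger carbon ring does not improve on the chain. Going by these compounds alone, this is the first measured step at this nitrogen. Nothing available explains this step. Still open, on these data alone, is how a methyl group, a cyclopropyl group or a longer chain such as butyl would read at this nitrogen, and whether a hydroxyethyl group would follow the same direction.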